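The compounds below may be only part of what the source reports. "The series", "measured", "known", "first", "only" and "open" are said of these compounds alone.

Of the compounds shown here, three of one shared core have been measured so far. Compound 1 `CC(C)(C)c1csc(N)c1C(=O)c1ccc(Cl)cc1`, compound 2 `CC(C)(C)Cc1csc(N)c1C(=O)c1cccc(Cl)c1` and compound 3 `CC(C)(C)Cc1c(-c2ccoc2)sc(N)c1C(=O)c1ccc(Cl)cc1` were each tested in an assay on CHO cells for displacement of a labelled ligand from adenosine receptor A3 (Homo sapiens), read by scintillation counting, tested at 10 uM; on this read-out higher numbers stand for more inhibition at the one concentration tested (going by the name of the read-out) and lower numbers for less inhibition. In this assay compound 1 gives 1%, compound 2 gives 8% and compound 3 gives 1%. Compound 3 thus sits level with compound 1 at the digits reported, and the two share the lowest reading of the three; the reading of compound 2 lies within the usual scatter of that of compound 3, so none of the three can be told apart on these numbers. All three sit near the bottom of the scale.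

Compound 4 `CC(C)(C)Cc1c(-c2cc(F)ccc2F)sc(N)c1C(=O)c1ccc(Cl)cc1` has not yet been measured. It differs from compound 3 in one place only: 2,5-difluorophenyl in place of furan-3-yl on an aromatic carbon. For the measured compounds named here, no pair of measured compounds differs in a single place, so nothing in the data shows how such a swap on the shared core changes the reading in this assay. The three readings at hand all lie low and within the scatter of one another.

With no measured single-place change to lean on, the step from compound 3 to compound 4 is expected to be a number 4 percentage points higher from compound 3 to compound 4 (within the scatter), that is, nothing beyond the scatter. Compound 4 is therefore estimated to give 5% in this assay, within a range from 0% to 20%.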

Compound 4, a percentage reported as inhibition, at one concentration (the size of the read-out at that concentration, not a potency): 1%
Beside the measured number, compound 4's estimate is 4 percentage points above it; low and high end bracket the measured number.
By their numbers in this assay, from the lowest: compounds 1, 3, 4 and 2 (each within the scatter of the next).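

For the compounds shown here, this is the first single-place change on the shared core that can be read: in this assay, putting 2,5-difluorophenyl in place of furan-3-yl on the aromatic carbon next to the ring sulfur gives no change at the digits printed from compound 3 to compound 4 (within the scatter) on this read-out. At this position, then, a five-membered aromatic ring with one oxygen and a six-membered aromatic ring of carbon only, carrying two fluorines, cannot be told apart, and losing the hydrogen-bond acceptor of furan-3-yl leaves no visible mark at the one concentration tested. No measurement at hand offers a reason for this result.

As far as these compounds go, because compound 3 and compound 4 both sit near the bottom of the scale, it stays open whether any group at this position can raise the reading at all, or whether a swap here would show up only on a compound that already reads higher. An amine, a carboxylic acid or a longer chain on this carbon would test whether the lack of change extends beyond aromatic rings.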